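The source may report more compounds than this note shows. Statements on the series, on what has been measured and on what is new or still open speak of the compounds shown alone.

Compound 1 `CC1CC/C(=N\Nc2cccc(Cl)c2)c2ncc(C(=O)O)c(=O)n21` gives 0.6 umol/kg in a functional assay on the whole organism for inhibition, with Rattus norvegicus as the target (on this read-out lower numbers stand for an effect already at smaller amounts and higher numbers for an effect only at larger amounts of compound), the lower of the two numbers shown, while compound 2 `CC1CC/C(=N\Nc2ccc(Br)cc2)c2ncc(C(=O)O)c(=O)n21` gives 0.8 umol/kg; the step of a 1.3-fold higher number from compound 1 to compound 2 (0.12 log units; within the scatter) lies within the scatter. Compound 3 `CC1CC/C(=N\Nc2cccc(C(=O)O)c2)c2ncc(C(=O)O)c(=O)n21` differs from compound 1 by carboxy in place of chloro on an aromatic carbon. Going by the values given here, no measured step introduces a carboxy group, and the single known step of a 1.3-fold higher number from compound 1 to compound 2 (0.12 log units; within the scatter) bears only loosely on this change. With so little to go on, compound 3 is expected to give 2 umol/kg in this assay, within a wide range from 0.5 umol/kg to 8 umol/kg. That expectation means a step of a 3.3-fold higher number from compound 1 to compound 3 (0.52 log units; beyond the scatter).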

Compound 3, dose for 50% inhibition: 26.6 umol/kg
The estimate for compound 3 lay 13-fold (1.12 log units) below the measured number; measured number above the stated range.
By their numbers in this assay, from the lowest: compounds 1 and 2 (each within the scatter of the next); then compound 3.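

In this assay, going by these compounds alone, this aromatic carbon proves far from indifferent: carboxy in place of chloro gives a 44-fold higher number from compound 1 to compound 3 (1.65 log units; beyond the scatter), whereas the only earlier step, which exchanged one halogen-bearing phenyl for another, stayed within the scatter. The earlier compounds shown here carried only halogens on this ring, so they gave no sign that a change of group here could shift the dose so strongly. No measurement offered here explains the shift. Going by these compounds, it remains open whether a methyl ester, a primary amide or a hydroxyl group on this carbon would stay near compound 1 or near compound 3.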